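Methoxy in Place of Hydrogen on the Benzoyl Ring

The source may report more compounds than this note shows. Statements on the series, on what has been measured and on what is new or still open speak of the compounds shown alone.

compound 1 `COc1cc(-c2nnc(SCC(=O)c3ccc(C)cc3)n2N2C(=O)c3ccccc3C2=O)cc(OC)c1OC`: 9440 nM
compound 2 `COc1cc(-c2nnc(SCC(=O)c3ccccc3)n2N2C(=O)c3ccccc3C2=O)cc(OC)c1OC`: 171000 nM

In a functional assay on HepG2 cells (Homo sapiens) for cytotoxicity, read by MTT assay, with a stated time of 48 h (on this read-out lower numbers stand for stronger inhibition and higher numbers for weaker inhibition), compound 2 stands at the higher of the two numbers, its nearest neighbour being compound 1, separated by the step of an 18-fold higher number from compound 1 to compound 2 (1.26 log units; beyond the scatter). Compound 3 `COc1ccc(C(=O)CSc2nnc(-c3cc(OC)c(OC)c(OC)c3)n2N2C(=O)c3ccccc3C2=O)cc1` differs from compound 2 by methoxy in place of hydrogen on an aromatic carbon, so that phenyl becomes 4-methoxyphenyl. Among the compounds with values here, the one measured step that bears on this carbon, an 18-fold higher number from compound 1 to compound 2 (1.26 log units; beyond the scatter), was large, and it shows that removing a group from this position went with a much higher number. Compound 3 is therefore expected to move back in the other direction, by a large step, an 11-fold lower number from compound 2 to compound 3 (1.06 log units; beyond the scatter). The value expected for compound 3 is 15000 nM, within a range of 4000 nM to 60000 nM.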

Compound 3, half-maximal inhibitory concentration: 28700 nM
Compound 3: middle estimate off by 1.9-fold (0.28 log units), on the low side; the range from low to high includes it.
By their numbers in this assay, from the lowest: compound 1; then compound 3; then compound 2.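

In this assay, methoxy in place of hydrogen on the benzoyl ring also goes with a lower number (a 6.0-fold lower number from compound 2 to compound 3 (0.78 log units; beyond the scatter)), so this effect at the position is not confined to methyl. The two groups do not match, however (a 3.0-fold higher number from compound 1 to compound 3 (0.48 log units; beyond the scatter)): the size of the drop depends on which group is present. Nothing available explains this difference. What the compounds shown leave open is whether chlorine, an amine or a carboxylic acid at this position would also go with a lower number than hydrogen.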